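Methyl on the distal phenyl of a weakly cytotoxic pair

The compounds below may be only part of what the source reports. "The series", "measured", "known", "first", "only" and "open" are said of these compounds alone.

Compound 1 `CC1=C(C(=O)OCc2ccccc2)C(c2ccc(-c3ccccc3)cc2)NC(=O)N1Cc1ccc(-c2nnn[nH]2)cc1` and compound 2 `CC1=C(C(=O)OCc2ccccc2)C(c2ccc(-c3ccccc3)cc2)NC(=S)N1CCCCCC(=O)O` were both tested in a toxicity assay on RMS13 cells (Homo sapiens) for inhibition, with a stated time of 24 h; on this read-out lower numbers stand for stronger inhibition of growth and higher numbers for weaker inhibition of growth. Compound 1 gives 96000 nM, and compound 2 gives 100000 nM; the two numbers lie within the scatter of each other, so neither can be set apart from the other. Compound 3 `CC1=C(C(=O)OCc2ccccc2)C(c2ccc(-c3ccccc3C)cc2)NC(=O)N1Cc1ccc(-c2nnn[nH]2)cc1` differs from compound 1 by methyl in place of hydrogen on an aromatic carbon. Without any measured step to lean on, the account expects compound 3 to show no step beyond the scatter from compound 1, so the estimated step is a 1.1-fold lower number from compound 1 to compound 3 (0.03 log units; within the scatter). On that basis compound 3 is estimated at 90000 nM, within a range from 40000 nM to 200000 nM.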

Compound 3, concentration for 50% growth inhibition: 73000 nM
Compound 3: the middle estimate sits 1.2-fold (0.09 log units) above what was measured, within the range that was stated.
By their numbers in this assay, from the lowest: compounds 3, 1 and 2 (each within the scatter of the next).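

In this assay, among the compounds shown here, the change from phenyl to 2-methylphenyl gives a 1.3-fold lower number from compound 1 to compound 3 (0.12 log units; within the scatter) and so offers the first reading at this place: a methyl on an aromatic carbon, ortho to a large group, is accepted with no shift that can be set apart from the scatter. No other measurement bears on this result. From the compounds shown here alone, whether an amine, a carboxylic acid or a longer chain at this same carbon would move the number beyond the scatter stays open, as does the effect of a methyl elsewhere on this ring.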